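The compounds below may be only part of what the source reports. "The series", "measured", "known", "first", "only" and "open" are said of these compounds alone.

Working notes on the series.

Compound 1 `Cn1nnnc1SCC(=O)N/N=C/c1ccc(Cl)cc1` is the reference point. In a functional assay on A549 cells (Homo sapiens) for cytotoxicity, read by XTT assay, with a stated time of 24 h (on this read-out higher numbers stand for weaker inhibition and lower numbers for stronger inhibition), compound 1 gives 100000 nM. Compound 2 `Cn1nnnc1SCC(=O)N/N=C/c1ccc(Br)cc1` differs from it by bromo in place of chloro on an aromatic carbon. The step is an at least 100-fold higher number from compound 1 to compound 2 (2.00 log units; beyond the scatter). For compound 2 the read-out is a limit of this assay, > 10000000 nM; what is known is the limit of > 10000000 nM in this assay, at which 1 of the 3 values shown sits.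

Compound 3 `Cn1nnnc1SCC(=O)N/N=C/c1cccc(Cl)c1` has the same atoms as compound 1 joined differently; the difference between the two cores is not broken down here. In this assay, among the compounds with values here, compound 3 gives 7500000 nM, the higher of the two numbers so far, with compound 1 beyond the scatter below it.

Compound 4 `Cn1nnnc1SCC(=O)N/N=C/c1cccc(Br)c1` is not yet measured. It differs from compound 3 by bromo in place of chloro on an aromatic carbon. Within the data shown here, this is the same kind of change as the one from compound 1 to compound 2, not the same: there the group sits para to a large group, here meta to a large group. Among the measured compounds shown here, the only measured instance of the change, a bromo in place of a chloro, moved the number upward by a large amount and into the limit region.

The step expected for compound 4 is a 2.7-fold higher number from compound 3 to compound 4 (0.43 log units; beyond the scatter), resting on an at least 100-fold higher number from compound 1 to compound 2 (2.00 log units; beyond the scatter) and on compound 3 already standing at 7500000 nM. Compound 4 is estimated near 20000000 nM, between 5000000 nM and 200000000 nM, with a real chance that this assay returns only a limit.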

Compound 4, half-maximal inhibitory concentration: 600000 nM
Beside the measured number, compound 4's estimate is 33-fold (1.52 log units) above it; measured number below the stated range.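

In this assay the bromo in place of chloro on an aromatic carbon gives a 13-fold lower number from compound 3 to compound 4 (1.10 log units; beyond the scatter), which runs opposite to the earlier instance of the same change, and the two steps clearly differ: the same change on two cores in this assay, an at least 100-fold higher number (2.00 log units; beyond the scatter) from compound 1 to compound 2 and a 13-fold lower number (1.10 log units; beyond the scatter) from compound 3 to compound 4, at least 1200-fold (3.09 log units) apart, beyond the scatter of two such steps

So in this series, the step seen on the core of compound 1 cannot be carried over to the core of compound 3 in either direction or size, and the earlier step is open-ended, since the read-out of compound 2 is only a limit: the limit of > 10000000 nM in this assay, at which 1 of the 4 values shown sits.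

These two pairs do not show what sets the steps apart, and they give no rule for predicting the change on any further core, only a warning that it depends on the core it is made on.

All four compounds shown carry a chloro or a bromo on the aromatic ring, so it remains open how a fluoro, a methoxy or an amine at that carbon would stand in this assay. Going by these compounds, it also remains open whether the same reversal would appear with a carboxylic acid or a longer chain in place of the halogen.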